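Working notes: substituent change from compound 2 to compound 3

The source may report more compounds than this note shows. Statements on the series, on what has been measured and on what is new or still open speak of the compounds shown alone.

Measured compounds:
Compound 1, `CCCCCCCCc1ccc(OCC(=O)Cn2nnc(-c3ccccc3)n2)cc1`: in an assay on microsomes from brain for inhibition of Fatty-acid amide hydrolase 1 (Rattus norvegicus), read by fluorescence and HPLC, with a stated time of 60 min (on this read-out higher numbers stand for weaker inhibition and lower numbers for stronger inhibition), compound 1 gives 24 nM.
Compound 2, `CCCCCCCCc1ccc(OCC(=O)Cn2nnc(C(=O)OC)n2)cc1`: in this assay compound 2 gives 88 nM.

Among the compounds with values here, compound 2 stands at the higher of the two numbers; its nearest neighbour is compound 1, reached by the step of a 3.7-fold higher number from compound 1 to compound 2 (0.56 log units; beyond the scatter), which is the only step within the set and lies beyond the scatter.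

The next compound, compound 3, `CCCCCCCCc1ccc(OCC(=O)Cn2nnc(-c3cccc(C(=O)O)c3)n2)cc1`, differs from compound 2 in one place: 3-carboxyphenyl in place of methoxycarbonyl on an aromatic carbon. The step from compound 1 to compound 2 bears directly on this, since it concerns the same position and shows that a phenyl group at this carbon gives a lower number than methoxycarbonyl. Within the data shown here, compound 3 carries a phenyl ring again, now bearing a carboxylic acid for which no measured compound gives guidance. The expectation is therefore a step back toward the number of compound 1, estimated as a 2.5-fold lower number from compound 2 to compound 3 (0.40 log units; beyond the scatter) in this assay. For compound 3 the estimate is 35 nM, expected to fall between 10 nM and 120 nM.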

Compound 3, half-maximal inhibitory concentration: 36 nM
Compound 3: the middle estimate sits 1.0-fold (0.01 log units) below what was measured; measured number inside the range.
By their numbers in this assay, from the lowest: compounds 1 and 3 (each within the scatter of the next); then compound 2.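

In this assay, 3-carboxyphenyl in place of methoxycarbonyl gives a 2.4-fold lower number from compound 2 to compound 3 (0.39 log units; beyond the scatter), so a second phenyl-bearing group at this aromatic carbon gives a lower number than methoxycarbonyl. With carboxy in place of hydrogen on the phenyl ring, the step reads a 1.5-fold higher number from compound 1 to compound 3 (0.18 log units; within the scatter), so the two numbers do not separate and the phenyl ring at this carbon accommodates the added group without a change beyond the scatter. No measurement at hand offers an explanation for either step.

The compounds shown leave open whether an amine or a nitrile in place of carboxy on the phenyl ring would also stay within the scatter. They also leave open what a carboxylic acid placed directly on this carbon, in place of methoxycarbonyl, would give.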